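Swapping fluoro-methylphenyl isomers on the amide nitrogen

A few compounds are considered here, and "the series" means these few. Any claim that something is new, unique, unknown or untested is made for them only; others in the source may bear on it.

Of the compounds shown here, three with a shared core have been measured. In an assay on cytosol from placenta for inhibition of 17-beta-hydroxysteroid dehydrogenase type 2 (Homo sapiens), read by HPLC, using microsomes, with a stated time of 10 min, in the presence of a further agent that is not named here (a lower number here means a stronger inhibitor, a higher number a weaker inhibitor), compound 1 `Cc1ccccc1N(C)C(=O)c1ccc(-c2cccc(O)c2)o1` gives 2800 nM. Compound 3 `Cc1cccc(F)c1N(C)C(=O)c1ccc(-c2ccc(O)cc2)o1` gives 3200 nM in this assay, the highest of the two numbers, though its gap to compound 1 lies within the scatter. Compound 2 `Cc1ccccc1N(C)C(=O)c1ccc(-c2ccccc2O)o1` reaches only the limit of this assay, > 10000 nM. Among the measured compounds shown here, the single step between measured compounds, an at least 3.5-fold higher number from compound 1 to compound 2 (0.55 log units; beyond the scatter), concerns the hydroxyphenyl and rests on (the limit of > 10000 nM in this assay, at which 1 of the 3 values shown sits).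

Compound 4 `Cc1ccc(F)cc1N(C)C(=O)c1ccc(-c2ccc(O)cc2)o1` has not yet been measured. It differs from compound 3 by 5-fluoro-2-methylphenyl in place of 2-fluoro-6-methylphenyl on an amide-type nitrogen whose other neighbours are a carbonyl carbon and a saturated chain carbon. No measured step touches this place: the only step shown is at the hydroxyphenyl, not on the amide-type nitrogen, so there is nothing in the data to suggest either direction. The change is therefore expected to give no step beyond the scatter in this assay, and the expected step is no change at the digits printed from compound 3 to compound 4 (within the scatter). Compound 4 is accordingly estimated at 3200 nM, with a range from 1100 nM to 9500 nM.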

Compound 4, half-maximal inhibitory concentration: 2200 nM
The estimate for compound 4 lay 1.5-fold (0.16 log units) above the measured number, within the range that was stated.
By their numbers in this assay, from the lowest: compounds 4, 1 and 3 (each within the scatter of the next). At a limit, above all of these: compound 2.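

Among the compounds shown here, compound 3 and compound 4 carry the same atoms on the amide-type nitrogen, joined differently, and this pair gives the first measured reading at that place. In this assay, for the compounds shown here, 5-fluoro-2-methylphenyl in place of 2-fluoro-6-methylphenyl gives a 1.5-fold lower number from compound 3 to compound 4 (0.16 log units; within the scatter), so this assay does not tell these two groups apart, whereas the earlier compounds showed a step only at the hydroxyphenyl. Nothing among the measurements offered bears on why these two groups read alike at this place.

What the compounds shown leave open is whether a different kind of group at this place, such as an amine or a carboxylic acid on the phenyl ring, or a longer chain on the amide-type nitrogen in place of the saturated chain carbon's methyl, would give a step beyond the scatter. Also open, from the compounds shown here alone, is whether the step seen at the hydroxyphenyl would recur with 5-fluoro-2-methylphenyl on the nitrogen, since both hydroxyphenyl isomers in that step carry a different group there.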